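Phenoxy for chloro: solubility outlook for compound 3

A few compounds are considered here, and "the series" means these few. Any claim that something is new, unique, unknown or untested is made for them only; others in the source may bear on it.

Compound 2 `O=[N+]([O-])c1cn2c(n1)OC[C@@H](NCc1ccc(OC(F)(F)F)cc1Cl)C2` gives 30 ug/mL in a physicochemical assay for solubility, at pH 6.8 (a higher number here means a more soluble compound, a lower number a less soluble compound), the lowest of the two numbers measured. Within the data shown here, its neighbour compound 1 `O=[N+]([O-])c1cn2c(n1)OC[C@@H](NCc1ccc(OC(F)(F)F)cc1F)C2` gives 72 ug/mL in this assay, and the step of a 2.4-fold lower number from compound 1 to compound 2 (0.38 log units; beyond the scatter) is the only measured step; it concerns the same aromatic carbon but a different group, so it bears only loosely on what follows. Compound 3 `O=[N+]([O-])c1cn2c(n1)OC[C@@H](NCc1ccc(OC(F)(F)F)cc1Oc1ccccc1)C2` differs from compound 2 thus: phenoxy in place of chloro on an aromatic carbon. The entering group is far larger than the chloro it replaces, and the step from compound 2 is expected to be a 5.0-fold lower number from compound 2 to compound 3 (0.70 log units; beyond the scatter), downward. Compound 3 is therefore estimated at 6 ug/mL, within 2 ug/mL to 18 ug/mL.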

Compound 3, solubility: 3 ug/mL
Beside the measured number, compound 3's estimate is 2.0-fold (0.30 log units) above it, and the stated range covers the measured number.
By their numbers in this assay, from the lowest: compound 3; then compound 2; then compound 1.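

Placing phenoxy on this aromatic carbon gives a 10-fold lower number from compound 2 to compound 3 (1.00 log units; beyond the scatter) in this assay and so moves the number further than the exchange of one halogen for another did. Measured against fluoro, the same group gives a 24-fold lower number from compound 1 to compound 3 (1.38 log units; beyond the scatter) as the largest step shown, which makes compound 3 the lowest of the three. No measurement shown bears on why the number falls. As far as these compounds go, whether an amine or a carboxylic acid on this carbon would raise the number stays open, as does the effect of a methoxy group, which would show whether the outcome follows the phenyl ring.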